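The source may report more compounds than this note shows. Statements on the series, on what has been measured and on what is new or still open speak of the compounds shown alone.

Compound 1 `O=C(Nc1ccccc1C(F)(F)F)C1CCc2ccccc2N1C(=O)c1ccccc1` in a functional assay on PC-3 cells (Homo sapiens) for cytotoxicity, read by sulforhodamine B assay, with a stated time of 72 h (on this read-out lower numbers stand for stronger inhibition of growth and higher numbers for weaker inhibition of growth), gives 5560 nM. Among the measured compounds shown here, compound 2 `O=C(Nc1cc(C(F)(F)F)cc(C(F)(F)F)c1)C1CCc2ccccc2N1C(=O)c1ccc(Cl)cc1` gives 4230 nM and compound 3 `O=C(Nc1ccccc1O)C1CCc2ccccc2N1C(=O)c1ccccc1` gives 5690 nM, so compound 1 sits among the others within the usual scatter; the one measured step, a 1.0-fold higher number from compound 1 to compound 3 (0.01 log units; within the scatter), moved nothing beyond that scatter. Compound 4 `CC(=O)N1c2ccccc2CCC1C(=O)Nc1ccccc1C(F)(F)F` differs from compound 1 by methyl in place of phenyl on a carbonyl carbon. For the measured compounds named here, no measured step touches this carbonyl-bound group, so the data give no guide to shrinking phenyl to methyl. Compound 4 is expected to show the step of a 1.4-fold higher number from compound 1 to compound 4 (0.16 log units; within the scatter), small and of uncertain direction, with a wide margin on both sides. Compound 4 is therefore estimated at 8000 nM, with a range from 3000 nM to 25000 nM.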

Compound 4, concentration for 50% growth inhibition: > 80000 nM
Compound 4 gave a limit, no number; the forecaster's own chance of this, stated with the estimate: 20%; at least 10-fold (1.00 log units) between middle value and limit.
By their numbers in this assay, from the lowest: compounds 2, 1 and 3 (each within the scatter of the next). At a limit, above all of these: compound 4.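

Among the compounds shown here, replacing phenyl with methyl on this carbonyl carbon, at the amide-type nitrogen in a ring, is the one measured change here that moves growth inhibition beyond the scatter, giving an at least 14-fold higher number from compound 1 to compound 4 (1.15 log units; beyond the scatter). For compound 4 the reading in this assay is a limit, not a number: the limit of > 80000 nM in this assay, at which 1 of the 4 values shown sits.

So in compound 1, the benzoyl group cannot be cut back to acetyl without a large loss of growth inhibition in this assay.

As far as these compounds go, the true size of this step stays open, since it rests on a limit. Also open, from the compounds shown here alone, is how a cyclohexyl group or a longer chain such as butyl would read on this carbonyl carbon, so it cannot be said whether an aromatic ring is needed here.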